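Phenyl in place of pyridin-3-yl on compound 2

The source may hold more compounds than are shown below. What is called first, only, known or untested is meant among the compounds shown, and "the series" means these compounds.

Measured in a physicochemical assay for solubility, in phosphate buffer, with a stated time of 18 h, at pH 7.4; a lower number here means a less soluble compound, a higher number a more soluble compound:
Compound 1 `COc1cc2ncnc(-n3nc(-c4ccccn4)nc3N)c2cc1[N+](=O)[O-]` gives 2000 nM
Compound 2 `COc1cc2ncnc(-n3nc(-c4cccnc4)nc3N)c2cc1OC` gives 27000 nM

In this assay compound 2 (27000 nM) holds the higher of the two numbers, beyond the scatter from compound 1. Compound 3 `COc1cc2ncnc(-n3nc(-c4ccccc4)nc3N)c2cc1OC` has phenyl in place of pyridin-3-yl on an aromatic carbon. Among the compounds with values here, no measured pair isolates this change, so the expectation rests on the structural change alone. A lower number is expected, beyond the scatter but moderate in size, with an estimated step of a 3.4-fold lower number from compound 2 to compound 3 (0.53 log units; beyond the scatter) in this assay. For compound 3 the estimated value is 8000 nM, with an expected range of 2000 nM to 25000 nM.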

Compound 3, solubility: 1000 nM
For compound 3 the middle estimate is 8.0-fold (0.90 log units) above the measured one; the measured number lies below the stated range.
By their numbers in this assay, from the lowest: compounds 3 and 1 (each within the scatter of the next); then compound 2.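

In this assay, within the data shown here, phenyl in place of pyridin-3-yl on the aromatic carbon of the five-membered ring gives a 27-fold lower number from compound 2 to compound 3 (1.43 log units; beyond the scatter), the first comparison that changes one place only. On the shared core, a single ring nitrogen exchanged for carbon at this position is therefore enough for a large step. No measurement at hand accounts for the size of this step. Compound 1 differs from both in more than one place and cannot settle this. Going by these compounds, how an amine such as morpholine or a carboxylic acid at this position would compare with compound 2 and compound 3 remains open.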